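A few compounds are considered here, and "the series" means these few. Any claim that something is new, unique, unknown or untested is made for them only; others in the source may bear on it.

Series notes. Compound 1 `O=C(Nc1cccc(-n2cc(-c3ccncc3)c(-c3ccc(Cl)c(O)c3)n2)c1)Nc1cc(C(F)(F)F)cc(C(F)(F)F)c1` and compound 2 `COc1cc(-c2nn(-c3cccc(NC(=O)Nc4cccc(C(F)(F)F)c4)c3)cc2-c2ccncc2)ccc1Cl` share a common core and differ in their outer substituents. In a functional assay on LOX IMVI cells (Homo sapiens) for inhibition, read by sulforhodamine B assay, with a stated time of 48 h (a higher number here means that more compound is tolerated, a lower number that less compound is tolerated), compound 1 gives 2750 nM, and compound 2 gives 3460 nM; compound 2 carries the higher of the two numbers, but its gap to compound 1 lies within the scatter, so neither can be ranked ahead of the other. Compound 3 `COc1cc(-c2nn(-c3cccc(NC(=O)c4ccccc4)c3)cc2-c2ccncc2)ccc1Cl` awaits measurement. It differs from compound 2 in one place: phenyl in place of (3-(trifluoromethyl)phenyl)amino on a carbonyl carbon. For the measured compounds named here, no measured pair covers such a change, so there is nothing to anchor the size of the step; the two values in hand only bracket where the series sits. The expected step in this assay is a 2.3-fold higher number from compound 2 to compound 3 (0.36 log units; beyond the scatter), toward a higher number, beyond the scatter. For compound 3 the estimated value in this assay is 8000 nM, with an expected range from 3000 nM to 25000 nM.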

Compound 3, concentration lethal to 50% of the cells: > 100000 nM
Compound 3 ended at the assay's limit; the forecaster's own chance of this, stated with the estimate: 15%; middle value at least 12-fold (1.09 log units) away from the limit.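

In this assay, phenyl in place of (3-(trifluoromethyl)phenyl)amino on the carbonyl carbon gives an at least 28-fold higher number from compound 2 to compound 3 (1.46 log units; beyond the scatter), the first single-place step available in the series. Compound 3 stands at a limit of the assay and not at a number, so the step gives only a bound on the change: the limit of > 100000 nM in this assay, at which 1 of the 3 values shown sits. This position is therefore sensitive, as one change here, with the rest of compound 2 kept, takes the number out of the measurable range of this assay.

The change removes the amino nitrogen, with the amide hydrogen, and the trifluoromethyl together, and the compounds shown do not separate the two. Phenylamino on the same carbonyl carbon, which keeps the nitrogen without the trifluoromethyl, would tell them apart.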